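Single enantiomer of compound 2: expected plasma exposure

A few compounds are considered here, and "the series" means these few. Any claim that something is new, unique, unknown or untested is made for them only; others in the source may bear on it.

Measured compounds:
- compound 1 `COc1ccccc1CNC1(CCC(C)(C)C)C(=O)C(C2=NS(=O)(=O)c3cc(NS(C)(=O)=O)ccc3N2)=C(O)c2ccccc21`: 613 nM
- compound 2 `Cc1cccc(C)c1CNC1(CCC(C)(C)C)C(=O)C(C2=NS(=O)(=O)c3cc(NS(C)(=O)=O)ccc3N2)=C(O)c2ccccc21`: 707 nM

Both were run in an in vivo ADME assay on the whole organism (strain Sprague-Dawley) for pharmacokinetics, with Rattus norvegicus as the target, at a dose of 5 mg/kg by the oral route; a lower number here means less compound in the circulation, a higher number more compound in the circulation at the dose given. Compound 1 gives 613 nM; compound 2 gives 707 nM. Within the data shown here, the only measured step, a 1.2-fold higher number from compound 1 to compound 2 (0.06 log units; within the scatter), changes the aryl group on the saturated chain carbon bound to the amine nitrogen and leaves the read-out within scatter, so compound 2 stands at the higher of the two numbers without separating from compound 1.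

Compound 3 `Cc1cccc(C)c1CN[C@]1(CCC(C)(C)C)C(=O)C(C2=NS(=O)(=O)c3cc(NS(C)(=O)=O)ccc3N2)=C(O)c2ccccc21` carries the same atoms and bonds as compound 2; the difference is the two compounds have the same atoms and bonds; at least one stereo element is drawn with a configuration in one of them and without one in the other: 1 of 1 stereo elements differ; a stereocentre at a saturated ring carbon is drawn without a configuration in compound 2 and S in compound 3. Among the measured compounds shown here, no measured step in this assay concerns a stereocentre, so nothing here tells whether one configuration is carried in the circulation differently from the undefined mixture. For the measured compounds named here, the step from compound 1 to compound 2 is the only comparison available and it is within scatter; it does not bear directly on a stereochemical change.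

Compound 3 is therefore expected to sit close to compound 2, with the step of a 1.1-fold higher number from compound 2 to compound 3 (0.03 log units; within the scatter) treated as no change beyond the scatter. The estimate for compound 3 is 750 nM, with a range from 350 nM to 1600 nM, widened to allow for the undocumented effect of fixing the configuration.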

Compound 3, maximal plasma concentration: 953 nM
Compound 3: the middle estimate sits 1.3-fold (0.10 log units) below what was measured; measured number inside the range.
By their numbers in this assay, from the lowest: compounds 1, 2 and 3 (each within the scatter of the next).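

In this assay, among these compounds, the first reading at this stereocentre is a 1.3-fold higher number from compound 2 to compound 3 (0.13 log units; within the scatter), so drawing the saturated ring carbon as S does not separate compound 3 from compound 2. The earlier compounds shown here tested only a change of aryl group, a 1.2-fold higher number from compound 1 to compound 2 (0.06 log units; within the scatter), and left the configuration at this carbon untouched; with this result, neither a change of aryl group nor a defined configuration has moved the maximal plasma concentration beyond the scatter among the compounds that differ in one place. The sole structural distinction in this pair is thus a matter of how the stereocentre is drawn, with no change of atoms or bonds, and the step gives no sign that this distinction matters for exposure at the dose given: the fact that one of compounds 2 and 3 is drawn with a defined configuration and the other without, at the place where they differ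

Open, going by these compounds, is how the R configuration at the same carbon would read, and what share of each configuration compound 2 contains. Also open, on these data alone, is whether a group of another kind, such as a carboxylic acid or a morpholine in place of the 2,6-dimethylphenyl, would shift the maximal plasma concentration beyond the scatter on the S configuration.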